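The compounds below may be only part of what the source reports. "The series", "measured", "known", "first", "only" and "open" are said of these compounds alone.

Compound 3 `CCCN(CCC)c1ccc(Nc2ncc(Cl)c(Oc3cccc(NC(=O)CC)c3)n2)c(OC)c1` is recorded in an assay on isolated protein for inhibition of NUAK family SNF1-like kinase 1 (Homo sapiens), read by ADP-Glo, with a stated time of 60 min, tested at 10 uM, in the presence of a further agent that is not named here (a higher number here means more inhibition at the concentration tested (going by the name of the read-out), a lower number less inhibition), as "not active" (no number reported), with no number given, so its place among the measured compounds can only be stated in words: it is reported as not active. Compound 1 `CCC(=O)Nc1cccc(Oc2nc(Nc3ccc(N(C)C)cc3OC)ncc2Cl)c1` is the measured member with the higher inhibition in this assay, and in this assay compound 1 gives 80.6%. Compound 2 `CCC(=O)Nc1cccc(Oc2nc(Nc3ccc(N4CCC(OC)CC4)cc3OC)ncc2Cl)c1` differs from compound 1 only at one aromatic carbon, and in this assay compound 2 gives 5.08%; the step of a number 75.5 percentage points lower from compound 1 to compound 2 (beyond the scatter) shows how much the exchange of a small dialkylamino group for a six-membered ring nitrogen costs at this position.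

Compound 4 `CCC(=O)Nc1cccc(Oc2nc(Nc3ccc(N4CCCCC4)cc3OC)ncc2Cl)c1` is obtained from compound 3 by the change (piperidin-1-yl in place of dipropylamino on an aromatic carbon). Going by the values given here, no measured step runs exactly between a dipropylamino and a piperidin-1-yl group, so the only bearing comes from the compounds carrying a six-membered ring nitrogen at this carbon: compound 2, whose number in this assay is lower, and compound 3, which is reported as not active. On that basis compound 4 is expected to show a low number for inhibition, and the estimate for compound 4 in this assay is 8%, with a range from 0% to 30%.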

Compound 4, a percentage reported as inhibition, at one concentration (the size of the read-out at that concentration, not a potency): 13.9%
Estimate against measurement, compound 4: 5.9 percentage points below, within the range that was stated.
By their numbers in this assay, from the lowest: compounds 2 and 4 (each within the scatter of the next); then compound 1.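

With the methoxy group gone from the saturated ring, the read-out in this assay shows a number 8.8 percentage points higher from compound 2 to compound 4 (within the scatter), so that methoxy group is not what separates compound 2 from compound 1. The plain piperidin-1-yl group still gives a number 66.7 percentage points lower from compound 1 to compound 4 (beyond the scatter), which shows that the large loss seen with the 4-methoxypiperidin-1-yl group also occurs without any substituent on the ring. No measurement given here explains why the dimethylamino group and the piperidin-1-yl group differ so widely at this aromatic carbon.

Going by these compounds, it remains open whether the loss comes from closing the alkyl chains into a ring or from the chains being longer than methyl, as compound 3, with its open dipropylamino chains, is also reported as not active. A diethylamino group or a pyrrolidin-1-yl group on this carbon would help to separate these two readings, and a morpholin-4-yl group would show whether a ring oxygen changes the picture.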